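Swapping Cyclobutyl for Dimethylamino on the Sulfonyl Sulfur

The source may report more compounds than this note shows. Statements on the series, on what has been measured and on what is new or still open speak of the compounds shown alone.

Measured so far:
Compound 1, `O=C([C@@H]1CCCN(S(=O)(=O)c2ccc(S(=O)(=O)C3CCC3)cc2)C1)N1CCC(F)(F)CC1`, gives 9 nM in a functional assay on MIA PaCa-2 cells (Homo sapiens) for inhibition, read by MTT assay, with a stated time of 7 days; a lower number here means a stronger inhibitor, a higher number a weaker inhibitor.
Compound 2, `CCN(CC)S(=O)(=O)c1ccc(S(=O)(=O)N2CCC[C@@H](C(=O)N3CCC(OC)CC3)C2)cc1`, gives 140 nM.
Compound 3, `CCN(CC)S(=O)(=O)c1ccc(S(=O)(=O)N2CCC[C@@H](C(=O)N3CCC(C(F)F)CC3)C2)cc1`, gives 420 nM.

Compound 1 has the lowest number of the three in this assay, and so is the strongest inhibitor among them; its gap to compound 2 and its larger gap to compound 3 both lie beyond the scatter of repeated measurements.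

Compound 4, `CN(C)S(=O)(=O)c1ccc(S(=O)(=O)N2CCC[C@@H](C(=O)N3CCC(F)(F)CC3)C2)cc1`, keeps the shared core of compound 1 and changes one place: dimethylamino in place of cyclobutyl on a sulfonyl sulfur.

For the measured compounds named here, no measured step touches that sulfonyl sulfur. Going by the values given here, the only measured step, a 3.0-fold higher number from compound 2 to compound 3 (0.48 log units; beyond the scatter), concerns a change on a saturated ring carbon elsewhere in the molecule, so it tells nothing direct about the present change. Compounds 2 and 3 do carry a dialkylamino group on that sulfur, and both give far higher numbers than compound 1. Each of them, however, also differs from compound 1 in a second place, so the data do not show how much of that gap goes with the sulfonyl change and how much with the other.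

A modest rise in the number is therefore expected for compound 4, with wide uncertainty: an estimated 25 nM, within a range of 8 nM to 80 nM, which would mean an expected step of a 2.8-fold higher number from compound 1 to compound 4 (0.44 log units; beyond the scatter).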

Compound 4, half-maximal inhibitory concentration: 118 nM
The estimate for compound 4 lay 4.7-fold (0.67 log units) below the measured number, outside the stated range (above it).
By their numbers in this assay, from the lowest: compound 1; then compounds 4 and 2 (each within the scatter of the next); then compound 3.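

In this assay, putting dimethylamino in place of cyclobutyl on the sulfonyl sulfur, with the rest of the molecule unchanged, gives a 13-fold higher number from compound 1 to compound 4 (1.12 log units; beyond the scatter). For the compounds shown here, this is the first step that isolates this position, and it shows that the group on this sulfur can by itself shift the number by a large amount, with no second change needed. The swap, cyclobutylsulfonyl to dimethylsulfamoyl, removes a four-membered carbon ring and brings in a nitrogen on the sulfur, but no supporting measurement separates these two parts of the change or explains the weaker inhibition of compound 4.

The compounds shown therefore leave open whether the ring or the carbon attached to the sulfur is what goes with the low number of compound 1. An isopropyl group on the same sulfur would keep a carbon there without a ring, whereas an azetidine attached through its nitrogen would keep a four-membered ring while placing a nitrogen on the sulfur, so these two groups would pull the two parts apart.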